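A Step Between Two Assay Limits

The compounds below may be only part of what the source reports. "The series", "measured", "known", "first", "only" and "open" are said of these compounds alone.

Measured compounds so far:
Compound 1, `C=CCSc1nnc(CCC)n1N1C(=O)c2ccccc2C1=O`: in a functional assay on A549 cells (Homo sapiens) for cytotoxicity, read by MTT assay, with a stated time of 48 h (a lower number here means a stronger inhibitor, a higher number a weaker inhibitor), compound 1 gives > 200000 nM, a limit of the assay rather than a number.
Compound 2, `CCCc1nnc(SCC(=O)c2ccccc2)n1N1C(=O)c2ccccc2C1=O`: in this assay compound 2 gives > 200000 nM, again a limit of the assay and not a number.

For the measured compounds named here, compound 2 therefore stands only at a limit in this assay, and the one further value shown is a limit as well, so nothing places compound 2 above or below compound 1 (the limit of > 200000 nM in this assay, at which 2 of the 2 values shown sit). Going by the values given here, the single measured step, a step that the two limits leave unreadable from compound 1 to compound 2, touches the same position as the change now considered, but its two limits leave its size unreadable.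

Compound 3 is `CCCc1nnc(SC)n1N1C(=O)c2ccccc2C1=O`. It differs from compound 2 by hydrogen in place of benzoyl on a saturated chain carbon bound to a sulfur. Among the compounds with values here, no measured step gives a readable size for a change of this kind, so no direction beyond the scatter can be drawn from the data; both measured compounds sit at the limit, and compound 3 is expected to sit there too. The step that the limit leaves unreadable from compound 2 to compound 3 is estimated to be flat, and compound 3 is estimated at 300000 nM, within 100000 nM to 1000000 nM.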

Compound 3, half-maximal inhibitory concentration: > 200000 nM
Compound 3 ended at the assay's limit (the forecaster's own chance of this, stated with the estimate: 90%); the middle value does not contradict the limit.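

In this assay compound 3 gives > 200000 nM, a limit of the assay and not a number. For the compounds shown here, no step among compound 1, compound 2 and compound 3 can therefore be read: the limit of > 200000 nM in this assay, at which 3 of the 3 values shown sit. The compounds shown leave open whether any group on the saturated chain carbon bound to a sulfur changes the value in this assay at all.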